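This account rests on a few compounds, and the source may have more. Where it says the series, first, only, none or still open, it means among the compounds named here.

In a functional assay on MDA-MB-435S cells (Homo sapiens) for cytotoxicity, read by MTT assay (on this read-out lower numbers stand for stronger inhibition and higher numbers for weaker inhibition), compound 3 `COc1ccc(-c2oc3c(CC=C(C)C)c(OCC(=O)O)cc(O)c3c(=O)c2OCC(=O)O)cc1` gives > 100000 nM, which is a limit of the assay and not a number. Compound 4 `COc1ccc(-c2oc3c(CC=C(C)C)c(OCC(=O)O)cc(O)c3c(=O)c2O)cc1` differs from it by a single change, (hydrogen in place of carboxymethyl on an oxygen on an aromatic ring), so that carboxymethoxy becomes hydroxy. Going by the values given here, no measured step covers this change directly. The nearest evidence is compound 1 `COc1ccc(-c2oc3c(CC=C(C)C)c(OC(C)C(=O)O)cc(O)c3c(=O)c2O)cc1` at 5700 nM and compound 2 `COc1ccc(-c2oc3c(CC=C(C)C)c(OC/C=C/C(=O)O)cc(O)c3c(=O)c2O)cc1` at 11300 nM, which both carry that hydroxy. Their step, a 2.0-fold higher number from compound 1 to compound 2 (0.30 log units; within the scatter), concerns the other substituted oxygen and stays within the scatter, so compound 4, with a carboxymethyl group there, is expected to fall near these two values. The expected move is large, an at least 12-fold lower number from compound 3 to compound 4 (1.09 log units; beyond the scatter), towards stronger inhibition. For compound 4 the estimate is 8000 nM, with an expected range from 2500 nM to 30000 nM.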

Compound 4, half-maximal inhibitory concentration: 13500 nM
Compound 4: the middle estimate sits 1.7-fold (0.23 log units) below what was measured; measured number inside the range.
By their numbers in this assay, from the lowest: compounds 1, 2 and 4 (each within the scatter of the next, the first and the last beyond it). At a limit, above all of these: compound 3.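

Compound 3 gives > 100000 nM in this assay, which is a limit of the assay and not a number. Hydrogen in place of carboxymethyl on this oxygen gives an at least 7.4-fold lower number from compound 3 to compound 4 (0.86 log units; beyond the scatter), towards stronger inhibition, the first step shown at this oxygen and the first beyond the scatter. On the other substituted oxygen the chain changes the number far less, with a 1.2-fold higher number from compound 2 to compound 4 (0.08 log units; within the scatter) and, as a modest step, a 2.4-fold higher number from compound 1 to compound 4 (0.37 log units; beyond the scatter).

The compounds shown leave open how a methyl ether or a longer chain on the hydroxy oxygen would read. They also leave open whether an amide or ester in place of the carboxylic acid on the other oxygen would hold the number.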